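Thioether side chain variations on the shared core

This account rests on a few compounds, and the source may have more. Where it says the series, first, only, none or still open, it means among the compounds named here.

Three compounds of the series carry a measurement in an ADME assay on GES1 cells (Homo sapiens) for inhibition, read by MTT assay, with a stated time of 72 h; on this read-out lower numbers stand for stronger inhibition and higher numbers for weaker inhibition. Compound 1 `Cc1cc(Nc2cc(-c3ccccc3)[nH]n2)n2nc(SCCc3ccccc3)nc2n1` gives 37400 nM. Compound 2 `Cc1cc(Nc2cc(-c3ccccc3)[nH]n2)n2nc(SCc3ccccc3Br)nc2n1` gives 41100 nM, and compound 3 `Cc1cc(Nc2cc(-c3ccccc3)[nH]n2)n2nc(SCc3ccc(C(F)(F)F)cc3)nc2n1` gives 42700 nM. Compound 1 holds the lowest of the three numbers, yet the step of a 1.1-fold higher number from compound 1 to compound 2 (0.04 log units; within the scatter) and the step of a 1.1-fold higher number from compound 1 to compound 3 (0.06 log units; within the scatter) both lie within the scatter, as does a 1.0-fold higher number from compound 2 to compound 3 (0.02 log units; within the scatter), so the three values are not separated from one another.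

Compound 4 `COc1ccc(CSc2nc3nc(C)cc(Nc4cc(-c5ccccc5)[nH]n4)n3n2)cc1` is not yet measured. Relative to compound 1 the change is 4-methoxyphenyl in place of benzyl on a saturated chain carbon bound to a sulfur. The measured steps of a 1.1-fold higher number from compound 1 to compound 2 (0.04 log units; within the scatter) and a 1.1-fold higher number from compound 1 to compound 3 (0.06 log units; within the scatter) each exchange benzyl on a saturated chain carbon bound to a sulfur for a substituted phenyl, and neither moved the number beyond the scatter. Within the data shown here, the change to compound 4 is of the same kind; the series holds no example of 4-methoxyphenyl at this place, so nothing further can be drawn from it. No step beyond the scatter is therefore expected in this assay, and the expected step reads a 1.1-fold higher number from compound 1 to compound 4 (0.03 log units; within the scatter). Compound 4 is estimated at 40000 nM, with a range from 20000 nM to 80000 nM.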

Compound 4, half-maximal inhibitory concentration: 28200 nM
Compound 4: the middle estimate sits 1.4-fold (0.15 log units) above what was measured; the measured number falls inside the stated range.
By their numbers in this assay, from the lowest: compounds 4, 1, 2 and 3 (each within the scatter of the next).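

Notes on the thioether side chain. In this assay, among these compounds, the step of a 1.3-fold lower number from compound 1 to compound 4 (0.12 log units; within the scatter) shows that 4-methoxyphenyl, the first entering group here with an oxygen and a hydrogen-bond acceptor, also leaves the number within the scatter, so this place on a saturated chain carbon bound to a sulfur has now taken an aromatic group with a methoxy as well as those with bromine and trifluoromethyl. The two widest gaps now available, a 1.5-fold lower number from compound 3 to compound 4 (0.18 log units; within the scatter) for methoxy in place of trifluoromethyl on an aromatic carbon and a 1.5-fold lower number from compound 2 to compound 4 (0.16 log units; within the scatter) for 4-methoxyphenyl in place of 2-bromophenyl, remain within the scatter too, so the four compounds form a single unresolved group with no ordering among the side chains. No supporting measurement accompanies these values, and the flat read-out therefore stays without an explanation.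

From the compounds shown here alone, whether an amine or a carboxylic acid on the aromatic ring, or a chain longer than phenethyl at this place, would produce a step beyond the scatter remains open. Also open, going by these compounds, is whether the same side chain changes stay within the scatter on a different core.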